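Biphenyl urea series: methoxy for fluoro at compound 3

A few compounds are considered here, and "the series" means these few. Any claim that something is new, unique, unknown or untested is made for them only; others in the source may bear on it.

Measured so far:
Compound 1, `Cc1ccc(CN2CCC(NC(=O)N(CC(=O)C(C)(C)O)Cc3ccc(-c4ccc(F)cc4)cc3)CC2)cc1` — 4530 nM
Compound 2, `Cc1ccc(CN2CCC(CCN(Cc3ccc(-c4ccc(F)cc4)cc3)C(=O)NC(C)C)CC2)cc1` — 383 nM

Both compounds were tested in an in vitro functional assay on HEK293 cells for antagonist activity at melanin-concentrating hormone receptor 1 (Homo sapiens), read by GTPgammaS binding, with a stated time of 45 min; on this read-out lower numbers stand for stronger inhibition and higher numbers for weaker inhibition. Compound 1 gives 4530 nM there. Compound 2 gives 383 nM and stands lowest of the two numbers; its gap to compound 1 is beyond the scatter, though the two differ at several places at once, so no single change can be read from that pair.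

Compound 3, `COc1ccc(-c2ccc(CN(CCC3CCN(Cc4ccc(C)cc4)CC3)C(=O)NC(C)C)cc2)cc1`, is not yet measured. It is built on compound 2 with one change: methoxy in place of fluoro on an aromatic carbon. The change sits on an aromatic carbon of a six-membered aromatic ring of carbon only, para to a large group; cut one bond further out it reads 4-fluorophenyl to 4-methoxyphenyl.

Going by the values given here, no measured pair shows this change, so no step size is known for it. The expectation is a step from compound 2 to compound 3 in this assay of about a 1.1-fold lower number from compound 2 to compound 3 (0.04 log units; within the scatter), that is, none beyond the scatter or at most a small one in either direction. Compound 3 is therefore estimated at 350 nM, with a range of 110 nM to 1200 nM.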

Compound 3, antagonist equilibrium constant: 467 nM
Beside the measured number, compound 3's estimate is 1.3-fold (0.13 log units) below it; low and high end bracket the measured number.
By their numbers in this assay, from the lowest: compounds 2 and 3 (each within the scatter of the next); then compound 1.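

In this assay the series now has its first pair differing in one place: 4-fluorophenyl to 4-methoxyphenyl gives a 1.2-fold higher number from compound 2 to compound 3 (0.09 log units; within the scatter) and so does not separate the two compounds. This position, para to a large group, therefore carries either fluoro, with 1 heavy atom and 0 hydrogen-bond acceptors, or methoxy, with 2 heavy atoms and 1 hydrogen-bond acceptor, and the read-out stays within the scatter across that difference, a point the earlier pair of compounds, differing at several places at once, could not show. Nothing measured on these compounds speaks to why the two groups read alike.

On these data alone, whether this result extends beyond these two groups stays open, since a chlorine, a trifluoromethyl, a nitrile, a hydroxyl or a plain hydrogen at the same place could read differently. Also open, as far as these compounds go, is whether methoxy in place of fluoro reads the same on the core of compound 1, which differs from the core of compound 2 at several places and stands at a much higher number.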